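Replacing the 2-aminoethyl amide with a diol amide

A few compounds are considered here, and "the series" means these few. Any claim that something is new, unique, unknown or untested is made for them only; others in the source may bear on it.

Among the measured compounds shown here, compound 2, `CCn1c(C(=O)NCCN)ccc1C(CC)(CC)c1ccc(OCCC(O)(CC)CC)c(C)c1`, stands second highest of the three numbers known in an assay on cells for agonist activity at vitamin D3 receptor (Homo sapiens), with a stated time of 96 h (a lower number here means that less compound is needed, a higher number that more compound is needed for the effect), with compound 2 giving 156 nM. Its nearest neighbour is compound 1, `CCn1c(C(=O)NCCCN(C)C)ccc1C(CC)(CC)c1ccc(OCCC(O)(CC)CC)c(C)c1`, for which compound 1 gives 5 nM; the step of a 31-fold higher number from compound 1 to compound 2 (1.49 log units; beyond the scatter). The furthest is compound 3, `C#CCCOC(=O)c1ccc(C(CC)(CC)c2ccc(OCCC(O)(CC)CC)c(C)c2)n1CC`, where compound 3 gives 6030 nM; the step of a 39-fold higher number from compound 2 to compound 3 (1.59 log units; beyond the scatter), and from the top of the series a 1200-fold higher number from compound 1 to compound 3 (3.08 log units; beyond the scatter).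

The unmeasured compound 4, `CCn1c(C(=O)NC(CO)CCO)ccc1C(CC)(CC)c1ccc(OCCC(O)(CC)CC)c(C)c1`, differs from compound 2 in one place: 3-hydroxy-1-(hydroxymethyl)propyl in place of 2-aminoethyl on an amide-type nitrogen. For the measured compounds named here, two measured steps bear on it. Changing the chain on the amide-type nitrogen, in the step from compound 1 to compound 2, gave a large rise, and removing that chain altogether, in the step from compound 2 to compound 3, gave another large rise. A further change at the same place is therefore expected to move the number in this assay upward, by a step beyond the scatter, though less far than the step to compound 3, since the amide remains. For compound 4 the estimate in this assay is 800 nM, within 150 nM to 4000 nM, which means an expected step of a 5.1-fold higher number from compound 2 to compound 4 (0.71 log units; beyond the scatter).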

Compound 4, half-maximal effective concentration: 2490 nM
For compound 4 the middle estimate is 3.1-fold (0.49 log units) below the measured one, within the range that was stated.
By their numbers in this assay, from the lowest: compound 1; then compound 2; then compound 4; then compound 3.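

In this assay, placing 3-hydroxy-1-(hydroxymethyl)propyl on the amide-type nitrogen brought a 16-fold higher number from compound 2 to compound 4 (1.20 log units; beyond the scatter) and, against the 3-(dimethylamino)propyl chain, a 500-fold higher number from compound 1 to compound 4 (2.70 log units; beyond the scatter) so keeping the amide did not by itself keep the number low. The amide with this chain lies much nearer the ester, with a 2.4-fold lower number from compound 3 to compound 4 (0.38 log units; beyond the scatter) as the remaining gap, and among these four compounds only the two amides whose chains carry an amine give the lowest numbers. No measurement shown accounts for these steps.

The compounds shown leave open whether the rise follows from losing the amine, from gaining the hydroxyl groups, or from the larger chain. A 2-hydroxyethyl or a 3-aminopropyl chain on the same nitrogen would help separate these readings.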